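A few compounds are considered here, and "the series" means these few. Any claim that something is new, unique, unknown or untested is made for them only; others in the source may bear on it.

Measured so far:
- compound 1, `CS(=O)(=O)c1cnc(C(=O)CCc2ccc(-c3ccccc3)cc2)o1`: 1.2 nM
- compound 2, `O=C(O)c1ccc(-c2cnc(CCCc3ccc(-c4ccccc4)cc3)o2)nc1`: 20000 nM

Both numbers come from an assay for inhibition of Fatty-acid amide hydrolase 1 (Rattus norvegicus); on this read-out higher numbers stand for weaker inhibition and lower numbers for stronger inhibition. Compound 1 gives 1.2 nM in this assay, and compound 2 gives 20000 nM in this assay. Of the two, compound 1 holds the lower number, and the gap to compound 2 lies well beyond the scatter of repeated measurements, so compound 1 is the stronger inhibitor of the two. Among the measured compounds shown here, compound 2 differs from compound 1 in several places at once, so no single structural step connects them and nothing more than the two values themselves can be read from that pair.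

The next compound, compound 3, is `COC(=O)c1cnc(C(=O)CCc2ccc(-c3ccccc3)cc2)o1`. It keeps the core of compound 1 and changes one group: methoxycarbonyl in place of methylsulfonyl on an aromatic carbon. The leaving and the entering group are alike in the counts above, with the same number of heavy atoms and of hydrogen-bond acceptors. For the measured compounds named here, no measured pair shows what this exchange does in this assay. Given that, the expected step of a 1.3-fold higher number from compound 1 to compound 3 (0.10 log units; within the scatter) is none beyond the scatter. Compound 3 is estimated at 1.5 nM, with a likely range from 0.3 nM to 8 nM.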

Compound 3, inhibition constant: 1.5 nM
Compound 3: middle estimate and measured number agree at the digits printed; the range from low to high includes it.
By their numbers in this assay, from the lowest: compounds 1 and 3 (each within the scatter of the next); then compound 2.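

In this assay, replacing methylsulfonyl with methoxycarbonyl on this aromatic carbon gives a 1.3-fold higher number from compound 1 to compound 3 (0.10 log units; within the scatter), so this read-out does not separate the two groups. Among the compounds shown here, compounds 1 and 3 are the first pair here that differ in only one place, and they show that, next to the ring oxygen, sulfur is not needed for a number of this size: a methoxycarbonyl group with the same heavy-atom and hydrogen-bond acceptor counts, but one fewer double bond outside aromatic rings, serves equally well on this read-out. No supporting measurement is available to explain this result.

Since the two groups match in those counts, the compounds shown leave open what a group of a different size or kind at this place would do, such as an amine, a single hydrogen atom or a longer alkyl chain. As far as these compounds go, compound 2, at 20000 nM, differs from the others in several places at once, so it also remains open which of those differences matter in this assay.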